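Restoring an Aryl Ether on the Shared Core

The source may hold more compounds than are shown below. What is called first, only, known or untested is meant among the compounds shown, and "the series" means these compounds.

Measured compounds:
compound 1 `COc1ccccc1Oc1ccc2c(NCCCNCc3ccco3)ccnc2c1` gives 14500 nM
compound 2 `Cc1cc(C)cc(Cc2ccc3c(NCCCNCc4ccco4)ccnc3c2)c1` gives 4200 nM
compound 3 `CCC(CC)c1ccc2c(NCCCNCc3ccco3)ccnc2c1` gives 4200 nM

These three values come from a physicochemical assay for solubility, with a stated time of 18 h, at pH 7.4; on this read-out higher numbers stand for higher solubility and lower numbers for lower solubility. Compound 3 stands level with compound 2 at the digits shown, and the two together are the lowest of the three numbers; its nearest neighbour is compound 2, where no change at the digits printed from compound 2 to compound 3 (within the scatter), and its furthest is compound 1, where a 3.5-fold lower number from compound 1 to compound 3 (0.54 log units; beyond the scatter).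

Compound 4 `CN(C)c1cccc(Oc2ccc3c(NCCCNCc4ccco4)ccnc3c2)c1` has not yet been measured in this assay. It differs from compound 3 in one place: 3-(dimethylamino)phenoxy in place of pentan-3-yl on an aromatic carbon.

Within the data shown here, the step that bears most directly on this change is the one between compound 1 and compound 3, where a 3.5-fold lower number from compound 1 to compound 3 (0.54 log units; beyond the scatter), since compound 1 also carries an aryl ether at the same position of the shared core. The step from compound 1 to compound 2, where a 3.5-fold lower number from compound 1 to compound 2 (0.54 log units; beyond the scatter), points the same way: the two compounds without an aryl ether sit below compound 1. Compound 4 returns an aryl ether to that position, so the expectation is a step upward in this assay, roughly reversing the step between compound 1 and compound 3. The step expected for compound 4 is a 2.9-fold higher number from compound 3 to compound 4 (0.46 log units; beyond the scatter). Compound 4 is therefore estimated at 12000 nM, with a likely range from 4000 nM to 35000 nM.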

Compound 4, solubility: 14500 nM
Compound 4: the middle estimate sits 1.2-fold (0.08 log units) below what was measured; measured number inside the range.
By their numbers in this assay, from the lowest: compounds 2 and 3 (each within the scatter of the next); then compounds 1 and 4 (each within the scatter of the next).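

On this aromatic carbon of the shared core, this assay now shows a second aryl ether standing apart from the two compounds without one, with a 3.5-fold higher number from compound 3 to compound 4 (0.54 log units; beyond the scatter) and a 3.5-fold higher number from compound 2 to compound 4 (0.54 log units; beyond the scatter). Exchanging the aryl group on the oxygen, 3-(dimethylamino)phenyl in place of 2-methoxyphenyl, gives no change at the digits printed from compound 1 to compound 4 (within the scatter), so the four compounds fall into two pairs, the aryl ethers on one side and the pentan-3-yl and 3,5-dimethylbenzyl compounds on the other, and none of the four goes against this split. No accompanying measurement speaks to what lies behind the split, which remains a description of these four compounds.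

The compounds shown leave open whether the split follows the ether oxygen or the particular groups at this position, as compound 2 keeps an aromatic ring on a carbon link but also carries two methyl groups. An unsubstituted phenoxy, an unsubstituted benzyl or a cyclohexyloxy on the same carbon would separate these readings in this assay, and a carboxylic acid on the phenoxy ring would show how far the number depends on the aryl group.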